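The source may hold more compounds than are shown below. What is called first, only, known or untested is meant among the compounds shown, and "the series" means these compounds.

In an ADME assay on MDCKII-LE cells (Canis lupus familiaris) for permeability, with a stated time of 1.5 h (a lower number here means that the compound crosses the layer more slowly, a higher number that the compound crosses the layer faster), three compounds have been measured:
compound 1 `Cc1cccnc1N(C(=O)N1CCC(c2ccccc2)CC1)[C@@H]1CCCNC1` gives 8.7 10^-6 cm/s;
compound 2 `Cc1cccnc1N(C(=O)N1CCC(c2ccccc2F)CC1)[C@@H]1CCCNC1` gives 9.5 10^-6 cm/s;
compound 3 `O=C(CCc1ccc(-n2nnc3cccnc32)cc1)N(c1ncccc1Cl)[C@@H]1CCCNC1` gives 15 10^-6 cm/s.

Compound 1 has the lowest of these three numbers, but the step of a 1.1-fold higher number from compound 1 to compound 2 (0.04 log units; within the scatter) is within the scatter, and the number for compound 3 also lies within the scatter of the number for compound 1, so the three are not truly separated. Compound 4 `Cc1nccnc1N(C(=O)N1CCC(c2ccccc2)CC1)[C@@H]1CCCNC1` differs from compound 1 in one place: 3-methylpyrazin-2-yl in place of 3-methylpyridin-2-yl on an amide-type nitrogen. Going by the values given here, the only measured step, from compound 1 to compound 2, exchanges hydrogen for fluoro on an aromatic carbon and leaves the group on the amide-type nitrogen unchanged, so it does not bear on this change; no measured pair exchanges one ring atom for another. With nothing to anchor it, the expected step of a 1.5-fold lower number from compound 1 to compound 4 (0.16 log units; within the scatter) is taken as small, downward if anything, and may well fall within the scatter. Compound 4 is therefore estimated at 6 10^-6 cm/s, with a range from 3 10^-6 cm/s to 12 10^-6 cm/s.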

Compound 4, apparent permeability: 11.5 10^-6 cm/s
Compound 4: middle estimate off by 1.9-fold (0.28 log units), on the low side, and the stated range covers the measured number.
By their numbers in this assay, from the lowest: compounds 1, 2, 4 and 3 (each within the scatter of the next).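

In this assay, going by these compounds alone, the exchange on the amide-type nitrogen gives a 1.3-fold higher number from compound 1 to compound 4 (0.12 log units; within the scatter), so a step at this position can now be read for the first time, the earlier step having concerned a fluoro on an aromatic carbon. With 3-methylpyrazin-2-yl in place of 3-methylpyridin-2-yl, the ring carries one more nitrogen and the group one more hydrogen-bond acceptor, yet the numbers for this pair are not separated. No measurement available here explains this result.

On these data alone, this is a single pair on one core, so it sets no general rule for this position, and whether the same exchange would give a similar step on compound 2 stays open. Also open, as far as these compounds go, is what an amine or a carboxylic acid in place of the methyl on this ring would do to the number.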